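Purine series: amino for hydrogen at the ring position

This account rests on a few compounds, and the source may have more. Where it says the series, first, only, none or still open, it means among the compounds named here.

Measured so far:
- compound 1, `ClCc1ccccc1Cn1cnc2c(Cl)nc(Cl)nc21`, 1450 nM
- compound 2, `ClCc1ccccc1Cn1cnc2c(Cl)ncnc21`, 22900 nM
- compound 3, `ClCc1cccc(Cn2cnc3c(Cl)ncnc32)c1`, 4570 nM

In a functional assay on TK-10 cells (Homo sapiens) for cytotoxicity, read by sulforhodamine B assay, with a stated time of 48 h (a higher number here means a weaker inhibitor of growth, a lower number a stronger inhibitor of growth), compound 2 gives the highest number of the three; compound 3 sits closest to it and compound 1 furthest, both beyond the scatter. Compound 4, `Nc1nc(Cl)c2ncn(Cc3ccccc3CCl)c2n1`, has yet to be measured. It differs from compound 2 by amino in place of hydrogen on an aromatic carbon: an amino group enters on the aromatic carbon between two ring nitrogen atoms, meta to a chloro group.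

Going by the values given here, only one measured step touches this carbon: a 16-fold higher number from compound 1 to compound 2 (1.20 log units; beyond the scatter), where chloro was replaced by hydrogen and the number rose sharply. Among the compounds with values here, the reverse direction, restoring a substituent there, points to a lower number, but no measured step involves an amino group, so the size is uncertain. A moderate step downward is expected, a 3.8-fold lower number from compound 2 to compound 4 (0.58 log units; beyond the scatter), smaller than the chloro effect. Compound 4 is estimated at 6000 nM, with a range from 1500 nM to 20000 nM.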

Compound 4, concentration for 50% growth inhibition: 17800 nM
For compound 4 the middle estimate is 3.0-fold (0.47 log units) below the measured one; the range from low to high includes it.
By their numbers in this assay, from the lowest: compound 1; then compound 3; then compounds 4 and 2 (each within the scatter of the next).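

In this assay, amino in place of hydrogen on the aromatic carbon between two ring nitrogen atoms does not separate the two compounds (a 1.3-fold lower number from compound 2 to compound 4 (0.11 log units; within the scatter)), so this change adds a new group here without a step beyond the scatter. The comparison with chloro at the same carbon is large (a 12-fold higher number from compound 1 to compound 4 (1.09 log units; beyond the scatter)), which shows that among compounds 1, 2 and 4 the sharp step belongs to chloro alone and not to any group placed on this carbon. Nothing available bears on why chloro and amino part so clearly here.

From the compounds shown here alone, whether a methyl, a methoxy or a fluoro at this carbon would follow chloro or amino stays open. Also open, going by these compounds, is whether amino on the core of compound 3 would give the same result.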